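The source may hold more compounds than are shown below. What is called first, only, known or untested is meant among the compounds shown, and "the series" means these compounds.

Working notes on the series.

Compound 1, `CCCCNC(=O)C1CCN(c2nc(N)c3cc(OC)c(OC)cc3n2)CC1`, in an assay on isolated protein for displacement of a labelled ligand from Adrenergic receptor alpha-1 (Rattus norvegicus) (on this read-out higher numbers stand for weaker inhibition and lower numbers for stronger inhibition), gives 0.67 nM. Compound 3, `CCN(CC)C(=O)C1CCN(c2nc(N)c3cc(OC)c(OC)cc3n2)CC1`, gives 1.11 nM in this assay. The change from compound 1 to compound 3 is diethylamino in place of butylamino on a carbonyl carbon and the step it made is a 1.7-fold higher number from compound 1 to compound 3 (0.22 log units; within the scatter), so the two amides read as equivalent within the usual scatter.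

Compound 2, `CCCCNC(=O)C1CCCN(c2nc(N)c3cc(OC)c(OC)cc3n2)C1`, gives 8.25 nM in this assay. The difference between the core of compound 2 and the core of compound 1 is not broken down here. Compound 2 carries the highest number of the three measured; its value set against that of compound 3 and that of compound 1 shows gaps that lie beyond the scatter, so the change of core weighs far more here than the change of amide.

Compound 4, `CCN(CC)C(=O)C1CCCN(c2nc(N)c3cc(OC)c(OC)cc3n2)C1`, has not yet been measured. It differs from compound 2 by diethylamino in place of butylamino on a carbonyl carbon, the same change that led from compound 1 to compound 3, at the same place on the carbonyl carbon. The step expected from compound 2 to compound 4 in this assay is a 1.7-fold higher number from compound 2 to compound 4 (0.23 log units; within the scatter), set beside the measured 1.7-fold higher number from compound 1 to compound 3 (0.22 log units; within the scatter). This rests on compound 1 and compound 3, whose step a 1.7-fold higher number from compound 1 to compound 3 (0.22 log units; within the scatter) stayed within the scatter. Compound 4 is therefore expected to give around 14 nM in this assay. The expected range for compound 4 runs from 5 nM to 40 nM.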

Compound 4, inhibition constant: 117 nM
For compound 4 the middle estimate is 8.4-fold (0.92 log units) below the measured one; the measured number lies above the stated range.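

In this assay, diethylamino in place of butylamino on a carbonyl carbon gives a 14-fold higher number from compound 2 to compound 4 (1.15 log units; beyond the scatter), so the step seen on the core of compound 1 does not carry over in size to the core of compound 2. Set side by side, the same change reads differently on the two cores: the same change on two cores in this assay, a 1.7-fold higher number (0.22 log units; within the scatter) from compound 1 to compound 3 and a 14-fold higher number (1.15 log units; beyond the scatter) from compound 2 to compound 4, 8.6-fold (0.93 log units) apart, beyond the scatter of two such steps This shows that, within these four compounds, the size of this change depends on the core that carries it, so a step read on one core is a poor guide to the other; it does not show why the two cores differ, whether other changes on the amide would diverge in the same way, or how the change would behave on any further core.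

Left open is which part of the change matters on the core of compound 2: propylamino, which keeps the amide hydrogen, and dimethylamino, which lacks it, would help separate the presence of that hydrogen from the length and branching of the chains. Also open, on these data alone, is whether the two cores diverge for amides in general, since each is seen here with only butylamino and diethylamino.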